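This account rests on a few compounds, and the source may have more. Where it says the series, first, only, none or still open, it means among the compounds named here.

Measured compounds: compound 1 `O=S(=O)(c1cccc(F)c1)c1cn(C2CCNC2)c2ncccc12` gives 44% in a functional assay on HeLa cells for agonist activity at 5-hydroxytryptamine receptor 6 (Homo sapiens), read by cAMP accumulation and immunoassay; a higher number here means a larger maximal response, a lower number a smaller maximal response; compound 2 `O=S(=O)(c1cccc(Br)c1)c1cn(C2CCNC2)c2ncccc12` gives 49%; compound 3 `O=S(=O)(c1cccc(Br)c1)c1cn(C2CCCNC2)c2ncccc12` gives 49%.

Compound 3 stands level with compound 2 in this assay: no change at the digits printed from compound 2 to compound 3 (within the scatter), where the two cores differ as follows: piperidin-3-yl in place of pyrrolidin-3-yl on an aromatic nitrogen. The change from compound 2 to compound 1 is fluoro in place of bromo on an aromatic carbon, and it gave a number 5 percentage points lower from compound 2 to compound 1 (within the scatter). The same change, (fluoro in place of bromo on an aromatic carbon), leads from compound 3 to compound 4 `O=S(=O)(c1cccc(F)c1)c1cn(C2CCCNC2)c2ncccc12`, which has not yet been measured in this assay; the place of the change is described in the same words for both pairs, so it is the same change. Compound 4 is expected to show a step of about a number 5 percentage points lower from compound 3 to compound 4 (within the scatter) from compound 3, because the earlier step was a number 5 percentage points lower from compound 2 to compound 1 (within the scatter). Compound 4 is therefore estimated at 44%, with a range from 34% to 55%.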

Compound 4, largest response reached (Emax), in percent of the reference or control that the assay uses: 84%
The estimate for compound 4 lay 40 percentage points below the measured number; measured number outside the range, above it.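

In this assay, fluoro in place of bromo on an aromatic carbon did not carry over from one core to the other, with the new step reading a number 35 percentage points higher from compound 3 to compound 4 (beyond the scatter) and differing from the earlier one: the same change on two cores in this assay, a number 5 percentage points lower (within the scatter) from compound 2 to compound 1 and a number 35 percentage points higher (beyond the scatter) from compound 3 to compound 4, 40 percentage points apart, beyond the scatter of two such steps. Seen from the other direction, piperidin-3-yl in place of pyrrolidin-3-yl on an aromatic nitrogen gave a number 40 percentage points higher from compound 1 to compound 4 (beyond the scatter) and also differed from its earlier step: the same change on two cores in this assay, no change at the digits printed (within the scatter) from compound 2 to compound 3 and a number 40 percentage points higher (beyond the scatter) from compound 1 to compound 4, 40 percentage points apart, beyond the scatter of two such steps. Thus, in these four compounds, the effect of each change depended on the other, but this single set of four shows neither why this happens nor whether it extends to other groups.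

The compounds shown leave open whether chloro or methoxy in place of fluoro on the aromatic carbon would behave as fluoro does on either core. They also leave open what a longer chain on the aromatic nitrogen would do.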